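From 2-hydroxyphenyl to 3-nitrophenyl on a shared core

This account rests on a few compounds, and the source may have more. Where it says the series, first, only, none or still open, it means among the compounds named here.

In a functional assay on cells (Homo sapiens) for cytotoxicity, read by MTT assay, with a stated time of 24 h (a lower number here means a stronger inhibitor, a higher number a weaker inhibitor), compound 1 (`CCCCCCCCCCCCCCNC(=O)[C@H](CO)/N=C/c1ccccc1[N+](=O)[O-]`) gives 21700 nM and compound 2 (`CCCCCCCCCCCCCCNC(=O)[C@H](CO)/N=C/c1ccccc1Cl`) gives 10300 nM and compound 3 (`CCCCCCCCCCCCCCNC(=O)[C@H](CO)/N=C/c1ccccc1O`) gives 19000 nM in this series. Compound 3 is second highest of these three numbers, yet within the scatter of both others. Compound 4 (`CCCCCCCCCCCCCCNC(=O)[C@H](CO)/N=C/c1cccc([N+](=O)[O-])c1`) carries 3-nitrophenyl in place of 2-hydroxyphenyl on a carbon with a double bond to nitrogen. Only the swaps on the aromatic ring bear on this: a 2.1-fold lower number from compound 1 to compound 2 (0.32 log units; beyond the scatter) is a modest step beyond the scatter, while a 1.8-fold higher number from compound 2 to compound 3 (0.27 log units; within the scatter) stays within it. Since a 1.1-fold lower number from compound 1 to compound 3 (0.06 log units; within the scatter) also stays within the scatter, no step beyond it is expected in this assay. The estimated step is small (a 1.1-fold lower number from compound 3 to compound 4 (0.02 log units; within the scatter)). Compound 4 is estimated at 18000 nM (range 9000 nM to 36000 nM).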

Compound 4, half-maximal inhibitory concentration: 104000 nM
Compound 4: middle estimate off by 5.8-fold (0.76 log units), on the low side; measured number above the stated range.
By their numbers in this assay, from the lowest: compounds 2, 3 and 1 (each within the scatter of the next, the first and the last beyond it); then compound 4.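

In this assay, going by these compounds alone, moving the nitro group on the ring gives a larger change than any seen among the earlier compounds: 3-nitrophenyl in place of 2-nitrophenyl gives a 4.8-fold higher number from compound 1 to compound 4 (0.68 log units; beyond the scatter). The same group also stands apart from the other two, with a 5.5-fold higher number from compound 3 to compound 4 (0.74 log units; beyond the scatter) against 2-hydroxyphenyl and a 10-fold higher number from compound 2 to compound 4 (1.00 log units; beyond the scatter) against 2-chlorophenyl. Nothing available explains this rise. As far as these compounds go, whether it belongs to the nitro group or to any group placed as in compound 4 stays open, and an amine or a carboxylic acid in place of that nitro group would test this.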